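Chain variation at the saturated carbon: hydroxy to formylmethyl

The compounds below may be only part of what the source reports. "The series", "measured", "known", "first", "only" and "open" are said of these compounds alone.

Compound 2 `COc1cccc(Sc2c(NS(=O)(=O)c3ccc(C(C)(C)C)cc3)noc2CO)c1` carries hydroxy on a saturated chain carbon bound to an aromatic carbon. Within the data shown here, in an assay on COS-7 cells for displacement of a labelled ligand from Endothelin receptor type B (Sus scrofa) (on this read-out higher numbers stand for weaker inhibition and lower numbers for stronger inhibition), compound 2 gives 560 nM, the highest of the two numbers measured so far. Its nearest neighbour is compound 1 `COC(=O)CCCc1onc(NS(=O)(=O)c2ccc(C(C)(C)C)cc2)c1Sc1cccc(OC)c1`, and in this assay compound 1 gives 310 nM. The step of a 1.8-fold higher number from compound 1 to compound 2 (0.26 log units; within the scatter) lies within the scatter, so the two compounds cannot be ranked against each other.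

Compound 3 `COc1cccc(Sc2c(NS(=O)(=O)c3ccc(C(C)(C)C)cc3)noc2CCC=O)c1` is the next member. The change is formylmethyl in place of hydroxy on a saturated chain carbon bound to an aromatic carbon. Among the measured compounds shown here, the only measured step that bears on this site is a 1.8-fold higher number from compound 1 to compound 2 (0.26 log units; within the scatter), where an ester-terminated chain was exchanged for hydroxy without moving the number beyond the scatter. For the measured compounds named here, compound 3 again alters this chain, now to one ending in a carbonyl, and on the single comparison available no step beyond the scatter is expected in this assay. The expected step is a 1.4-fold lower number from compound 2 to compound 3 (0.15 log units; within the scatter). Compound 3 is estimated at 400 nM, with a range from 150 nM to 1100 nM.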

Compound 3, half-maximal inhibitory concentration: 500 nM
Compound 3: the middle estimate sits 1.3-fold (0.10 log units) below what was measured, and the stated range covers the measured number.
By their numbers in this assay, from the lowest: compounds 1, 3 and 2 (each within the scatter of the next).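

In this assay, among these compounds, the step of a 1.1-fold lower number from compound 2 to compound 3 (0.05 log units; within the scatter) is the first reading of a chain end with no hydrogen-bond donor against hydroxy, which has one, and the number does not move beyond the scatter. The step of a 1.6-fold higher number from compound 1 to compound 3 (0.21 log units; within the scatter) also stays within the scatter, so the ester-terminated chain of compound 1, the hydroxy of compound 2 and the carbonyl-terminated chain of compound 3 cannot be told apart on this read-out, and across these three compounds the site shows no measurable response to the chain end. No supporting measurement is available to account for this flat reading.

Going by these compounds, what remains open is whether a carboxylic acid or an amine at the end of this chain, or a longer chain, would carry the number beyond the scatter. All three compounds share one core, so the reading applies to this chain on that core alone and says nothing about how the same chain ends would behave with any other group on the core.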